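Swapping a Nitrile for a Methyl on Two Cores

The source may report more compounds than this note shows. Statements on the series, on what has been measured and on what is new or still open speak of the compounds shown alone.

Compound 1 `Cc1cc(C)c(Oc2cc(Nc3ccc(C#N)cc3)[nH]c(=O)c2I)c(C)c1`, compound 2 `Cc1cc(C#N)cc(C)c1Oc1cc(Nc2ccc(C#N)cc2)[nH]c(=O)c1I` and compound 3 `COc1cc(Oc2c(C)cc(C)cc2C)cc(Nc2ccc(C#N)cc2)n1` have been tested in an ADME assay on MT4 cells (Homo sapiens) for cytotoxicity, read by MTT assay, with a stated time of 5 days; a lower number here means that less compound is tolerated, a higher number that more compound is tolerated. Compound 1 gives 34000 nM in this assay. For compound 2 this assay reports only a limit, > 259000 nM, which is not a number. Compound 3 gives 29000 nM in this assay, which sits within the usual scatter of the value of compound 1.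

Compound 2 and compound 1 differ in one place, (methyl in place of cyano on an aromatic carbon). That change brings an at least 7.6-fold lower number from compound 2 to compound 1 (0.88 log units; beyond the scatter), a step that is bounded only on one side because of the limit of > 259000 nM in this assay, at which 1 of the 3 values shown sits.

Compound 4 `COc1cc(Oc2c(C)cc(C)cc2C)cc(Nc2ccc(C)cc2)n1` is not yet measured. It differs from compound 3 by methyl in place of cyano on an aromatic carbon. Within the data shown here, this is the same kind of change as the one from compound 2 to compound 1, though the surroundings are not identical: in compound 2 the cyano sits meta to two methyl groups and para to a large group, whereas in compound 3 it sits only para to a large group. How the core of compound 3 differs from the core of compound 2 is not broken down here.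

Given that compound 2 to compound 1 showed an at least 7.6-fold lower number from compound 2 to compound 1 (0.88 log units; beyond the scatter), a step in the same direction is expected for compound 4, though smaller, since the earlier one is only a bound. The expected step is a 2.9-fold lower number from compound 3 to compound 4 (0.46 log units; beyond the scatter), and the estimate for compound 4 in this assay is 10000 nM, between 3000 nM and 30000 nM.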

Compound 4, half-maximal cytotoxic concentration: 35000 nM
Compound 4: the middle estimate sits 3.5-fold (0.54 log units) below what was measured; the whole stated range lies below it.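

In this assay, replacing the nitrile with a methyl on the core of compound 3 brings a 1.2-fold higher number from compound 3 to compound 4 (0.08 log units; within the scatter), so the clear fall seen in the earlier pair does not carry over to this second pair: the same change on two cores in this assay, an at least 7.6-fold lower number (0.88 log units; beyond the scatter) from compound 2 to compound 1 and a 1.2-fold higher number (0.08 log units; within the scatter) from compound 3 to compound 4, at least 9.1-fold (0.96 log units) apart, beyond the scatter of two such steps

Compound 2 is reported only as a limit, > 259000 nM, which is not a number, so the earlier step has no fixed size. The two pairs show that the same named swap need not give the same result in this series, but they do not show why, as the cores differ and compound 1 still carries the 4-cyanophenyl group that is lost from compound 3 to compound 4, so the two swaps do not touch the same nitrile.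

The compounds shown leave open whether an amine, a carboxylic acid or a longer chain in place of that methyl would also stay within the scatter of compound 3. They also leave open how the change would behave on a third core, since two pairs cannot set a rule for the series.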